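Amide aryl variation on the shared aminoquinoline core

This account rests on a few compounds, and the source may have more. Where it says the series, first, only, none or still open, it means among the compounds named here.

Three amides on the shared core have numbers in a functional assay on A375P cells (Homo sapiens) for antiproliferative activity, read by MTT assay, with a stated time of 48 h; a higher number here means a weaker inhibitor, a lower number a stronger inhibitor. Compound 1 `COc1ccc(C(=O)Nc2cccc(-c3ccnc4c(N)cccc34)c2)cc1OC` gives 9500 nM. Compound 2 `Cc1cc(C(=O)Nc2cccc(-c3ccnc4c(N)cccc34)c2)ccc1Br` gives 9900 nM. Compound 3 `Nc1cccc2c(-c3cccc(NC(=O)c4ccc5c(c4)OCCO5)c3)ccnc12` gives 860 nM, the lowest of the three, set apart from both others: an 11-fold lower number from compound 1 to compound 3 (1.04 log units; beyond the scatter) and a 12-fold lower number from compound 2 to compound 3 (1.06 log units; beyond the scatter), whereas a 1.0-fold higher number from compound 1 to compound 2 (0.02 log units; within the scatter).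

Compound 4 `Nc1cccc2c(-c3cccc(NC(=O)c4nccs4)c3)ccnc12` is not yet measured. Its change from compound 3 is 1,3-thiazol-2-yl in place of 2,3-dihydro-1,4-benzodioxin-6-yl on a carbonyl carbon. Within the data shown here, no measured step swaps an aryl amide for a five-membered heteroaryl amide, so nothing bears on it directly. What the measured steps show is that the group on the carbonyl carbon matters: two substituted phenyl groups sit together near the weak end, and the 2,3-dihydro-1,4-benzodioxin-6-yl group stands apart as the strong one. Losing that group is therefore expected to cost activity, and the step from compound 3 to compound 4 is estimated at a 4.7-fold higher number from compound 3 to compound 4 (0.67 log units; beyond the scatter), back toward the range of compound 1 and compound 2 rather than below it. For compound 4 the expected value in this assay is 4000 nM, estimated to lie between 800 nM and 20000 nM.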

Compound 4, half-maximal inhibitory concentration: 16700 nM
Compound 4: middle estimate off by 4.2-fold (0.62 log units), on the low side; the range from low to high includes it.
By their numbers in this assay, from the lowest: compound 3; then compounds 1, 2 and 4 (each within the scatter of the next).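

In this assay, among these compounds, the 1,3-thiazol-2-yl group on the carbonyl carbon gives the first reading of a five-membered aromatic ring at this position, and it does not keep the low number of the 2,3-dihydro-1,4-benzodioxin-6-yl amide: the swap gives a 19-fold higher number from compound 3 to compound 4 (1.29 log units; beyond the scatter). The new amide cannot be told apart from the two substituted phenyl amides, with a 1.7-fold higher number from compound 2 to compound 4 (0.23 log units; within the scatter) and a 1.8-fold higher number from compound 1 to compound 4 (0.24 log units; within the scatter), so three different groups now sit together and the 2,3-dihydro-1,4-benzodioxin-6-yl group remains the only one of the four set apart. Nothing available on these compounds accounts for that separation.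

On these data alone, it remains open whether the low number depends on the six-membered non-aromatic ring with its two oxygens, a question that a 1,3-benzodioxol-5-yl group or an unsubstituted phenyl group on the carbonyl carbon would address. Also open, as far as these compounds go, is whether a five-membered aromatic ring can approach compound 3 once it carries a further group, such as an aminomethyl group or a carboxylic acid.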